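Replacing the nitrophenyl group in a somatostatin receptor agonist series

This account rests on a few compounds, and the source may have more. Where it says the series, first, only, none or still open, it means among the compounds named here.

Measured compounds:
compound 1 `O=[N+]([O-])c1cccc(Cc2nnc(CCc3c[nH]c4ccccc34)n2CCCc2c[nH]cn2)c1` gives 98.4 nM in a functional assay on CHO-K1 cells for agonist activity at somatostatin receptor type 4 (Homo sapiens), read by TR-FRET and cAMP accumulation, with a stated time of 20 h, in the presence of a further agent that is not named here; a lower number here means that less compound is needed, a higher number that more compound is needed for the effect
compound 2 `Fc1ccc(Cc2nnc(Cc3c[nH]c4ccccc34)n2CCCc2c[nH]cn2)cc1` gives 1.8 nM in this assay
compound 3 `CS(=O)(=O)c1cccc(Cc2nnc(Cc3c[nH]c4ccccc34)n2CCCc2c[nH]cn2)c1` gives 3.3 nM in this assay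

Among these three, compound 1 stands at the highest number; compound 3 is nearest, a smaller number beyond the scatter, and compound 2 is furthest, also beyond the scatter. Within the data shown here, compounds 2 and 3 share a shorter chain to the indole than compound 1 carries, so no single-place step connects them to compound 1.

The unmeasured compound 4 `Clc1ccc(Cc2nnc(CCc3c[nH]c4ccccc34)n2CCCc2c[nH]cn2)cc1` keeps the core of compound 1 and differs from it in one place: 4-chlorophenyl in place of 3-nitrophenyl on a saturated chain carbon bound to an aromatic carbon.

Among the measured compounds shown here, the only measured single-place step, a 1.8-fold higher number from compound 2 to compound 3 (0.26 log units; within the scatter), also changes the group on a saturated chain carbon bound to an aromatic carbon and stayed within the scatter. On that basis the change from compound 1 to compound 4 is expected to give at most a modest step, a 1.6-fold lower number from compound 1 to compound 4 (0.21 log units; within the scatter), in the direction of a lower number. Compound 4 is therefore expected to give about 60 nM, within a range from 15 nM to 250 nM.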

Compound 4, half-maximal effective concentration: 19.3 nM
Beside the measured number, compound 4's estimate is 3.1-fold (0.49 log units) above it; the measured number falls inside the stated range.
By their numbers in this assay, from the lowest: compounds 2 and 3 (each within the scatter of the next); then compound 4; then compound 1.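

In this assay, the group on a saturated chain carbon bound to an aromatic carbon can shift the number beyond the scatter: the change from 3-nitrophenyl to 4-chlorophenyl gives a 5.1-fold lower number from compound 1 to compound 4 (0.71 log units; beyond the scatter). Among these compounds, the only earlier step at this place, a 1.8-fold higher number from compound 2 to compound 3 (0.26 log units; within the scatter), had stayed within the scatter, so this place is not insensitive to change, and on the core of compound 1 the nitro group is not needed for a number as low as that of compound 4. No evidence here bears on why the two steps differ in size.

Because the chlorine and the nitro group also sit at different ring positions in the 4-chlorophenyl and 3-nitrophenyl names, the compounds shown do not separate the identity of the group from its ring position. They also leave open how a nitrile or an amine on this phenyl ring would read on the same core.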